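Bromo in Place of Hydrogen: From Compound 2 to Compound 3

This account rests on a few compounds, and the source may have more. Where it says the series, first, only, none or still open, it means among the compounds named here.

Compound 1, `CSc1ccc2c(c1)c(O)c(S(=O)(=O)N(C)c1ccccc1)c(=O)n2C`: 53%
Compound 2, `CN1C(=O)/C(=C(/S)N(C)c2ccccc2)C(=O)c2ccccc21`: 85%

Of the compounds shown here, two have so far been measured in a functional assay on the whole organism with Mus musculus as the target, at a dose of 32 mg/kg by the oral route; on this read-out higher numbers stand for more inhibition at the one dose given (going by the name of the read-out) and lower numbers for less inhibition. Compound 1 `CSc1ccc2c(c1)c(O)c(S(=O)(=O)N(C)c1ccccc1)c(=O)n2C` gives 53% in this assay. Compound 2 `CN1C(=O)/C(=C(/S)N(C)c2ccccc2)C(=O)c2ccccc21` gives 85% in this assay, the higher of the two numbers, and its gap to compound 1 lies beyond the usual scatter. For the measured compounds named here, compounds 1 and 2 differ in more than one place, so only their two values can be set side by side; no single-change step between them is available.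

Compound 3 `CN1C(=O)/C(=C(/S)N(C)c2ccccc2)C(=O)c2cc(Br)ccc21` has not yet been measured. It differs from compound 2 in one place: bromo in place of hydrogen on an aromatic carbon. Going by the values given here, the data hold no step that shows how such a change moves the read-out. The anchor is compound 2 with its 85% in this assay. The expected step of a number 5 percentage points lower from compound 2 to compound 3 (within the scatter) is small, none beyond the scatter, in either direction. Compound 3 is therefore expected to give about 80% in this assay, within a range from 55% to 95%.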

Compound 3, a percentage reported as inhibition, in the whole organism at one dose (the size of the read-out at that dose, not a potency): 98%
Compound 3: the middle estimate sits 18 percentage points below what was measured, outside the stated range (above it).
By their numbers in this assay, from the lowest: compound 1; then compound 2; then compound 3.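

In this assay, for the compounds shown here, bromo in place of hydrogen on an aromatic carbon gives a number 13 percentage points higher from compound 2 to compound 3 (beyond the scatter), the first single-change step available and the first direct reading of what a substituent does at this position. It shows that this carbon of the six-membered aromatic ring of carbon only can carry a bromo group, one heavy atom with no hydrogen-bond donors or acceptors, without any loss at the one dose given, and that the read-out here responds to the change in an upward direction. The data offer nothing that accounts for the direction or size of this step.

A single step with a single substituent cannot say whether chloro, fluoro, methoxy, a nitrile or a carboxylic acid on the same carbon would move the read-out the same way, or whether bromo on another carbon of this ring would do so. Because the read-out reports the size of the effect at one dose, it also leaves open how compound 2 and compound 3 would compare at other doses.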